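Phenyl for 1-methyl-1H-pyrazol-4-yl on compound 1

A few compounds are considered here, and "the series" means these few. Any claim that something is new, unique, unknown or untested is made for them only; others in the source may bear on it.

Measured in a functional assay on NCI-H1993 cells (Homo sapiens) for inhibition, read by CCK-8 assay, with a stated time of 72 h; a higher number here means a weaker inhibitor, a lower number a stronger inhibitor:
compound 1 (`CC(c1cc(F)c2ncccc2c1)n1cnc2ncc(-c3cnn(C)c3)nc21`): > 10000 nM (a limit)
compound 2 (`CC(c1c(F)cc2ncccc2c1F)n1cnc2ncc(-c3cnn(C)c3)nc21`): 35.5 nM
compound 3 (`Cc1c(C(C)n2cnc3ncc(-c4cnn(CCO)c4)nc32)ccc2ncccc12`): 726 nM

Compound 1 stands at the limit of > 10000 nM in this assay, at which 1 of the 3 values shown sits, and so offers a limit rather than a number. Compound 2 and compound 3 give numbers, but neither differs from compound 1 in one place only. Compound 4 (`CC(c1cc(F)c2ncccc2c1)n1cnc2ncc(-c3ccccc3)nc21`) carries phenyl in place of 1-methyl-1H-pyrazol-4-yl on an aromatic carbon. Within the data shown here, no measured step bears on this change. In this assay no step beyond the scatter is expected in either direction, and compound 4 may also return only a limit. The estimated change is small (a number no higher from compound 1 to compound 4 (the limit leaves the size open)). For compound 4 the expected value is 10000 nM (estimated range 3000 nM to 30000 nM).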

Compound 4, half-maximal inhibitory concentration: > 10000 nM
Compound 4: only a limit was reported (the forecaster's own chance of this, stated with the estimate: 65%); the middle value lies on the limit itself.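

In this assay no step can be read from compound 1 to compound 4, as both are reported only as limits: the limit of > 10000 nM in this assay, at which 2 of the 4 values shown sit.
The compounds shown leave open whether phenyl and 1-methyl-1H-pyrazol-4-yl differ in effect on this core.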